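Swapping an aryl back in at the triazole substituent

This account rests on a few compounds, and the source may have more. Where it says the series, first, only, none or still open, it means among the compounds named here.

Measured so far in a functional assay on HeLa cells (Homo sapiens) for antiproliferative activity, read by MTT assay, with a stated time of 72 h; on this read-out higher numbers stand for weaker inhibition and lower numbers for stronger inhibition:
- compound 1, `COc1ccccc1-c1cn(C[C@H](O)[C@H]2OC(=O)C(OCc3ccccc3)=C2OCc2ccccc2)nn1`: > 100000 nM (a limit of the assay)
- compound 2, `CCCCCCCCCCc1cn(C[C@H](O)[C@H]2OC(=O)C(OCc3ccccc3)=C2OCc2ccccc2)nn1`: 22900 nM
- compound 3, `CC(C)(C)c1cn(C[C@H](O)[C@H]2OC(=O)C(OCc3ccccc3)=C2OCc2ccccc2)nn1`: 18300 nM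

Three compounds share one core and differ only in the group on an aromatic carbon of the triazole. Compound 1 gives only a limit, (the limit of > 100000 nM in this assay, at which 1 of the 3 values shown sits), so no number is known for it. Compound 2 and compound 3 give numbers within the scatter of each other, so neither can be ranked ahead of the other; compound 3 simply holds the lower of the two numbers shown.

Compound 4, `O=C1O[C@H]([C@@H](O)Cn2cc(-c3cc(F)cc(F)c3)nn2)C(OCc2ccccc2)=C1OCc1ccccc1`, changes compound 3 by 3,5-difluorophenyl in place of tert-butyl on an aromatic carbon. For the measured compounds named here, the steps that bear on it are those that removed an aryl group: an at least 4.3-fold lower number from compound 1 to compound 2 (0.64 log units; beyond the scatter) and an at least 5.4-fold lower number from compound 1 to compound 3 (0.73 log units; beyond the scatter), both beyond the scatter, each a lowering of the number. Putting an aromatic ring back in therefore points toward a higher number, though the ring now carries two fluorines rather than a methoxy group, so the size is uncertain. The expected step is a 2.7-fold higher number from compound 3 to compound 4 (0.44 log units; beyond the scatter). Compound 4 is estimated at 50000 nM, with a range from 15000 nM to 150000 nM.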

Compound 4, half-maximal inhibitory concentration: 40800 nM
Compound 4: middle estimate off by 1.2-fold (0.09 log units), on the high side, and the stated range covers the measured number.
By their numbers in this assay, from the lowest: compounds 3, 2 and 4 (each within the scatter of the next, the first and the last beyond it). At a limit, above all of these: compound 1.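

In this assay, an aromatic ring on this carbon does not by itself push the number out of reach: 3,5-difluorophenyl in place of 2-methoxyphenyl gives an at least 2.4-fold lower number from compound 1 to compound 4 (0.38 log units; beyond the scatter). That step is only a bound, as compound 1 stands at a limit of the assay: the limit of > 100000 nM in this assay, at which 1 of the 4 values shown sits. Against the two alkyl groups, the ring gives a 2.2-fold higher number from compound 3 to compound 4 (0.35 log units; beyond the scatter), a modest step beyond the scatter, whereas a 1.8-fold higher number from compound 2 to compound 4 (0.25 log units; within the scatter) stays within it, so the change can be read against tert-butyl but not against decyl.

On these data alone, what remains open is whether the fluorines, the methoxy group or their places on the ring separate compound 4 from compound 1, a question that a plain phenyl group would help to settle. Also open, as far as these compounds go, is how a ring-free group carrying an amine or a carboxylic acid would fare at this carbon.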